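The source may report more compounds than this note shows. Statements on the series, on what has been measured and on what is new or still open speak of the compounds shown alone.

In a functional assay on ECV-304 cells (Homo sapiens) for cytotoxicity (on this read-out lower numbers stand for stronger inhibition and higher numbers for weaker inhibition), compound 1 (`O=C1/C(=C/c2ccc(Cl)c(Cl)c2)SC(=S)N1NS(=O)(=O)c1ccccc1`) gives > 50000 nM, which is a limit of the assay and not a number. Compound 2 (`O=C1/C(=C/c2ccc(F)c(F)c2F)SC(=S)N1NS(=O)(=O)c1ccccc1`) gives > 50000 nM, which is also only a limit, so compound 2 stands with no measured number. Compound 3 (`O=C1/C(=C/c2cc(F)c(F)cc2F)SC(=S)N1NS(=O)(=O)c1ccccc1`) has the same atoms as compound 2, joined differently: 2,4,5-trifluorophenyl in place of 2,3,4-trifluorophenyl on a double-bonded chain carbon bound to a double-bonded ring carbon, with 2,4,5-trifluorophenyl in place of 2,3,4-trifluorophenyl. Among the compounds with values here, the one measured step that bears on this change is a step that the two limits leave unreadable from compound 1 to compound 2, and it has no readable size. The evidence is the limit of > 50000 nM in this assay, at which 2 of the 2 values shown sit. Both aryl variants tested so far thus sit at the limit, and no size or direction of change can be drawn from them. The expected outcome is a number no higher from compound 2 to compound 3 (the limit leaves the size open), a step estimated to lie within the scatter. For compound 3, the estimate is 50000 nM, with an expected range of 25000 nM to 100000 nM, and a report as a limit is the likeliest result.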

Compound 3, half-maximal inhibitory concentration: > 50000 nM
Compound 3 gave a limit, no number; the forecaster's own chance of this, stated with the estimate: 85%; the middle value lies on the limit itself.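

In this assay compound 3 gives > 50000 nM, which is a limit and not a number, so no new step can be read among compound 1, compound 2 and compound 3. The compounds shown leave open whether any change at this place would yield a measurable number: the limit of > 50000 nM in this assay, at which 3 of the 3 values shown sit.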